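A few compounds are considered here, and "the series" means these few. Any claim that something is new, unique, unknown or untested is made for them only; others in the source may bear on it.

Measured compounds:
compound 1 `Cc1nc(-c2ccsc2)sc1COc1ccc2c(c1)OCC2CC(=O)O` — 56.5%
compound 2 `Cc1nc(-c2cccc(Cl)c2)sc1COc1ccc2c(c1)OCC2CC(=O)O` — 43%
compound 3 `Cc1nc(-c2ccc(Cl)cc2)sc1COc1ccc2c(c1)OCC2CC(=O)O` — 53.4%

In a functional assay on CHO cells for agonist activity at Free fatty acid receptor 1 (Homo sapiens), read by FLIPR and calcium flux, tested at 100 nM (a lower number here means a weaker effect, a higher number a stronger effect of the compound at the concentration tested), compound 3 gives 53.4%, the second highest of the three numbers. Its nearest neighbour is compound 1, since a number 3.1 percentage points lower from compound 1 to compound 3 (within the scatter); its furthest is compound 2, since a number 10.4 percentage points higher from compound 2 to compound 3 (beyond the scatter). Compound 4 `Cc1nc(-c2cccc(C(F)(F)F)c2)sc1COc1ccc2c(c1)OCC2CC(=O)O` differs from compound 3 in one place: 3-(trifluoromethyl)phenyl in place of 4-chlorophenyl on an aromatic carbon.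

Going by the values given here, two measured steps bear on this change. The step of a number 10.4 percentage points higher from compound 2 to compound 3 (beyond the scatter) shows that shifting a chloro substituent between the two positions on the phenyl ring moved the activity by a modest amount, and a number 13.5 percentage points lower from compound 1 to compound 2 (beyond the scatter) shows the 3-chlorophenyl compound as the lowest of the set. Among the compounds with values here, no measured compound carries a trifluoromethyl group, so the effect of that exchange itself is unknown; the account can rest only on the position pattern. A modest decrease in this assay is therefore expected, with a number 9.4 percentage points lower from compound 3 to compound 4 (within the scatter). Compound 4 is estimated to give 44%, in the range 30% to 58%.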

Compound 4, a percentage reported as activity, at one concentration (the size of the read-out at that concentration, not a potency): 35.7%
Compound 4: the middle estimate sits 8.3 percentage points above what was measured; low and high end bracket the measured number.
By their numbers in this assay, from the lowest: compounds 4 and 2 (each within the scatter of the next); then compounds 3 and 1 (each within the scatter of the next).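

In this assay the exchange of chloro for trifluoromethyl on the 3-substituted phenyl ring can now be read directly: a number 7.3 percentage points lower from compound 2 to compound 4 (within the scatter) and so the 3-chlorophenyl and 3-(trifluoromethyl)phenyl groups cannot be told apart. Against the other two groups at this place on the five-membered ring, the new compound shows a number 17.7 percentage points lower from compound 3 to compound 4 (beyond the scatter) and a number 20.8 percentage points lower from compound 1 to compound 4 (beyond the scatter) so the low standing of compound 2 is now shared by a second 3-substituted phenyl group, among these four compounds. Nothing measured here explains these differences. 

As far as these compounds go, it remains open whether trifluoromethyl in the position that chloro holds in compound 3 would match that compound or fall with compound 4. Also open, from the compounds shown here alone, is how an amine or a methoxy group on the phenyl ring would read in this assay at this place.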